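Side-chain swap on the shared core: outlook for compound 3

The source may hold more compounds than are shown below. What is called first, only, known or untested is meant among the compounds shown, and "the series" means these compounds.

Working notes on the series. The two measured compounds share one core. Compound 1 `CC(C)(O)c1cn(Cc2nnc(-c3cc(S(N)(=O)=O)c(SCc4ccccc4)cc3Cl)o2)nn1` carries a 4-(1-hydroxy-1-methylethyl)-1H-1,2,3-triazol-1-yl group on a saturated chain carbon bound to an aromatic carbon; in an ADME assay on microsomes from liver (Homo sapiens) for metabolic stability, read by LC-MS, using NADPH, tested at 5 uM (on this read-out higher numbers stand for a longer-lived compound and lower numbers for a shorter-lived compound), compound 1 gives 0.23 h. Compound 2 `NS(=O)(=O)c1cc(-c2nnc(CNS(=O)(=O)c3ccc(Cl)cc3)o2)c(Cl)cc1SCc1ccccc1` carries ((4-chlorophenyl)sulfonyl)amino in that place; in this assay compound 2 gives 0.197 h. The step of a 1.2-fold lower number from compound 1 to compound 2 (0.07 log units; within the scatter) lies within the scatter, so compound 2 and compound 1 cannot be told apart on these numbers; compound 2 stands as one of two results that are effectively the same.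

Compound 3 `NS(=O)(=O)c1cc(-c2nnc(/C=C/c3ccccc3)o2)c(Cl)cc1SCc1ccccc1` differs from compound 2 in one place: 2-phenylethenyl in place of (((4-chlorophenyl)sulfonyl)amino)methyl on an aromatic carbon. Going by the values given here, only one measured step bears on a change at this position, a 1.2-fold lower number from compound 1 to compound 2 (0.07 log units; within the scatter), and it did not move this assay beyond the scatter even though the whole side group was exchanged. Nothing in the data separates a 2-phenylethenyl group from either earlier substituent, so no step beyond the scatter is expected in this assay, i.e. a 1.0-fold higher number from compound 2 to compound 3 (0.01 log units; within the scatter). Compound 3 is therefore estimated at 0.2 h in this assay, with a range from 0.1 h to 0.4 h.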

Compound 3, half-life: 0.228 h
Estimate against measurement, compound 3: 1.1-fold (0.06 log units) below, within the range that was stated.
By their numbers in this assay, from the lowest: compounds 2, 3 and 1 (each within the scatter of the next).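

Working notes, continued. In this assay the exchange gives a 1.2-fold higher number from compound 2 to compound 3 (0.06 log units; within the scatter), and the wider exchange gives a 1.0-fold lower number from compound 1 to compound 3 (0.00 log units; within the scatter), so the three side groups cannot be told apart on half-life. What compound 3 adds is a side group of a different kind: 2-phenylethenyl is built of carbon only, has 0 hydrogen-bond donors and 0 hydrogen-bond acceptors, and has no saturated chain carbon on the ring, whereas compound 1 and compound 2 both carry such a carbon and their groups contain nitrogen and oxygen, yet none of these differences separates the numbers at this position. Nothing at hand accounts for the three results lying so close together.

As far as these compounds go, all three compounds keep the rest of the shared core unchanged, so it remains open whether a change outside this position would move the half-life beyond the scatter. From the compounds shown here alone, it also remains open whether a small group at this position, such as an aminomethyl group or a carboxylic acid, would read differently from the three larger side groups compared here.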